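Ethoxy in place of amino in the series

This account rests on a few compounds, and the source may have more. Where it says the series, first, only, none or still open, it means among the compounds named here.

Compound 1 (`CCOc1ccccc1-c1ncc(C(=O)O)c(=O)[nH]1`) stands at 0.5 mg/kg in a functional assay on the whole organism (strain Sprague-Dawley) for inhibition, with Rattus norvegicus as the target, with a stated time of 10 min (a higher number here means that more compound is needed for the effect, a lower number that less compound is needed), and compound 2 (`CCOC(=O)c1cnc(-c2ccccc2Cl)[nH]c1=O`) stands at 5 mg/kg there. Compound 3 (`CCOC(=O)c1cnc(-c2ccccc2N)[nH]c1=O`) has no number to stand on: its result is "not determined" (no result reported) in this assay and it cannot be placed against the other two. The next structure is compound 4 (`CCOC(=O)c1cnc(-c2ccccc2OCC)[nH]c1=O`). The change is ethoxy in place of amino on an aromatic carbon. With no number for compound 3, no size or direction of step can be expected from it. The expectation rests instead on compound 1 (0.5 mg/kg), which also carries ethoxy, and compound 2 (5 mg/kg), which shares the ethyl ester, so a value between the two is expected. The estimated dose for compound 4 is 2.5 mg/kg (expected range 0.7 mg/kg to 8 mg/kg).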

Compound 4, dose for 50% inhibition: 2 mg/kg
Estimate against measurement, compound 4: 1.3-fold (0.10 log units) above, within the range that was stated.
By their numbers in this assay, from the lowest: compound 1; then compound 4; then compound 2.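

Ethoxy in place of chloro on the aromatic carbon gives a 2.5-fold lower number from compound 2 to compound 4 (0.40 log units; beyond the scatter) in this assay and so gives this position its first readable step within the ethyl esters. With ethoxy held constant, ethyl on the acid oxygen gives a 4.0-fold higher number from compound 1 to compound 4 (0.60 log units; beyond the scatter) and so puts the free acid ahead of its ethyl ester in this pair. The step from amino cannot be read, and no measured data explain either readable step.

From the compounds shown here alone, whether methoxy or a longer chain such as propoxy at this position shifts the dose further stays open. So does whether the gap between ethoxy and chloro holds with a carboxylic acid or a methyl ester on the core.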